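The source may hold more compounds than are shown below. What is called first, only, known or untested is meant among the compounds shown, and "the series" means these compounds.

Working notes on the series.

Compound 3 `Cc1ccccc1-n1nncc1CN1C(=O)C2(C(C#N)=C(N)Oc3c(N)cc4nc5ccccc5nc4c32)c2ccccc21` reaches only a limit in a functional assay on HepG2 cells (Homo sapiens) for antiproliferative activity, read by MTT assay, with a stated time of 48 h (on this read-out higher numbers stand for weaker inhibition and lower numbers for stronger inhibition), namely > 50000 nM. Compound 1 `Cc1cccc(-n2nncc2CN2C(=O)C3(C(C#N)=C(N)Oc4c3c3nc5ccccc5nc3c3ccccc43)c3ccccc32)c1` likewise sits at a limit, > 50000 nM. Within the data shown here, compound 2 `N#CC1=C(N)Oc2c(c3nc4ccccc4nc3c3ccccc23)C12C(=O)N(Cc1cnnn1-c1ccc(S(N)(=O)=O)cc1)c1ccccc12` is the one compound with a number, giving 42200 nM. Among the measured compounds shown here, the single measured step, an at least 1.1-fold lower number from compound 1 to compound 2 (0.07 log units; that floor lies within the scatter), stays within the scatter, and the limit of > 50000 nM in this assay, at which 2 of the 3 values shown sit, shows how little room the numbers leave. Compound 4 `N#CC1=C(N)Oc2c(N)cc3nc4ccccc4nc3c2C12C(=O)N(Cc1cnnn1-c1cc(Cl)ccc1Cl)c1ccccc12` differs from compound 3 by 2,5-dichlorophenyl in place of 2-methylphenyl on an aromatic nitrogen. For the measured compounds named here, no measured step touches a 2,5-dichlorophenyl, so the only guide is the step from compound 1 to compound 2, which was flat. Compound 4 is therefore expected to stay near the limit, with a number no higher from compound 3 to compound 4 (the limit leaves the size open) meaning no step beyond the scatter; the estimate for compound 4 is 50000 nM, ranging from 20000 nM to 100000 nM.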

Compound 4, half-maximal inhibitory concentration: 33100 nM
Compound 4: the middle estimate sits 1.5-fold (0.18 log units) above what was measured; the range from low to high includes it.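

The core of compound 3 shows an at least 1.5-fold lower number from compound 3 to compound 4 (0.17 log units; that floor lies within the scatter) with this change, so a second core now gives a measured number with a new group on this aromatic nitrogen, though no step beyond the scatter. Only the floor of the step can be read, and its true size stays open: the limit of > 50000 nM in this assay, at which 2 of the 4 values shown sit.

Still open, going by these compounds, is whether an amine or a carboxylic acid on the phenyl ring, or a longer alkyl chain in place of that ring, would give a step clear of the scatter.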